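One more methyl on the chain of compound 3

The source may report more compounds than this note shows. Statements on the series, on what has been measured and on what is new or still open speak of the compounds shown alone.

Measured in an ADME assay on HFF cells (Homo sapiens) for cytotoxicity, with a stated time of 8 days; on this read-out lower numbers stand for higher toxicity in this test and higher numbers for lower toxicity in this test:
- Compound 1 `CC(C)Nc1nc(N)nc2c1ncn2/C=C1/CC1(CO)CO` gives > 300000 nM (a limit of the assay)
- Compound 2 `Nc1nc(N2CCCC2)c2ncn(/C=C3/CC3(CO)CO)c2n1` gives > 300000 nM (a limit of the assay)
- Compound 3 `CCCCCOc1nc(N)nc2c1ncn2/C=C1/CC1(CO)CO` gives 259000 nM

Compound 3 is the only one of the three with an actual number in this assay, namely 259000 nM. All that is known of the others is the limit of > 300000 nM in this assay, at which 2 of the 3 values shown sit.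

Compound 4 `CCCCCCOc1nc(N)nc2c1ncn2/C=C1/CC1(CO)CO` differs from compound 3 by a single change: methyl in place of hydrogen on a saturated chain carbon, five bonds along the chain from an oxygen on an aromatic ring. Among the compounds with values here, no measured step makes this change. The nearest evidence comes from the two steps that arrive at the pentyloxy group: an at least 1.1-fold lower number from compound 1 to compound 3 (0.06 log units; that floor lies within the scatter) and an at least 1.1-fold lower number from compound 2 to compound 3 (0.06 log units; that floor lies within the scatter). Both are only floors, and neither shows a change beyond the scatter. The remaining step, a step that the two limits leave unreadable from compound 1 to compound 2, gives no size at all. The two readable steps also replace a whole group on an aromatic carbon, whereas compound 4 only gains a methyl, and they are a weak guide.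

In this assay, no step beyond the scatter is expected, with a slight lean towards a lower number, the direction of those two floors. The expected step is a 1.3-fold lower number from compound 3 to compound 4 (0.11 log units; within the scatter). For compound 4 the estimated value is 200000 nM. The expected range for compound 4 runs from 90000 nM to 350000 nM.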

Compound 4, half-maximal cytotoxic concentration: > 200000 nM
Compound 4 was reported as a limit; the forecaster's own chance of this, stated with the estimate: 30%; the middle value lies on the limit itself.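

In this assay compound 4 gives > 200000 nM, which is a limit of the assay. None of the steps from compound 1, compound 2 or compound 3 to compound 4 can be read. The compounds shown leave open whether methyl in place of hydrogen on the chain of compound 3 changes the number at all, and in which direction.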